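Ester chain to methyl ether: working notes

The source may hold more compounds than are shown below. What is called first, only, known or untested is meant among the compounds shown, and "the series" means these compounds.

- compound 1 `C=C[C@@](C)(/C=C/c1ccc(OC(=O)CCC)cc1)CCC=C(C)C`: 54%
- compound 2 `C=C[C@@](C)(/C=C/c1ccc(OC(=O)CCCCCCC)cc1)CCC=C(C)C`: 62%

Among the measured compounds shown here, in a functional assay on THP-1 cells (Homo sapiens) for inhibition, with a stated time of 48 h, tested at 50 uM (on this read-out higher numbers stand for more inhibition of growth at the one concentration tested and lower numbers for less inhibition of growth), compound 2 stands within the scatter of compound 1, its only measured neighbour. For the measured compounds named here, the single measured step is a number 8 percentage points higher from compound 1 to compound 2 (within the scatter). That step alters only the chain on the carbonyl, which stays in place.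

Next for measurement is compound 3 `C=C[C@@](C)(/C=C/c1ccc(OC)cc1)CCC=C(C)C`, with methyl in place of heptylcarbonyl on an oxygen on an aromatic ring. Going by the values given here, the carbonyl goes with this change, and no measured compound lacks it, so the measured step bears on the change only weakly. A moderate fall is tentatively expected, with its size poorly fixed by the data. The expected step is a number 14 percentage points lower from compound 2 to compound 3 (beyond the scatter). The estimate for compound 3 is 48%, with an expected range of 28% to 66%.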

Compound 3, percent growth inhibition at one concentration: 45%
Compound 3: middle estimate off by 3 percentage points, on the high side; measured number inside the range.
By their numbers in this assay, from the lowest: compounds 3, 1 and 2 (each within the scatter of the next, the first and the last beyond it).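

Working notes on the oxygen on the aromatic ring: in this assay, methyl in place of heptylcarbonyl gives a number 17 percentage points lower from compound 2 to compound 3 (beyond the scatter), the first step in the series beyond the scatter and the first to remove the carbonyl. Methyl in place of propylcarbonyl gives a number 9 percentage points lower from compound 1 to compound 3 (within the scatter), so the change reads differently against the two esters, and a difference appears only against the longer one. Growth inhibition does not depend entirely on the ester, as compound 3 without a carbonyl still gives 45%, and no measurement available accounts for the step.

Methyl changes chain length and removes the carbonyl at once, so the share of each remains open. A longer chain joined as an ether, or a free hydroxyl on the same oxygen, would bear on that question.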